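Replacing Diethylamino with (Oxetan-3-yl)amino

The compounds below may be only part of what the source reports. "The series", "measured", "known", "first", "only" and "open" are said of these compounds alone.

In an ADME assay on microsomes from liver (Rattus norvegicus) for metabolic stability, using NADPH, with a stated time of 10 min (on this read-out higher numbers stand for a more stable compound and lower numbers for a less stable compound), compound 1 `NCCCCN(C[C@H]1Cc2ncccc2CN1)[C@H]1CCCc2cccnc21` gives 64%, compound 2 `NC(=O)NC/C=C/CN(C[C@H]1Cc2ncccc2CN1)[C@H]1CCCc2cccnc21` gives 1% and compound 3 `CCN(CC)CCCCN(C[C@H]1Cc2ncccc2CN1)[C@H]1CCCc2cccnc21` gives 6%. Compound 3 therefore sits level with compound 2, since the step of a number 5 percentage points higher from compound 2 to compound 3 (within the scatter) is small, and far from compound 1. Compound 4 `c1cnc2c(c1)CN[C@@H](CN(CCCCNC1COC1)[C@H]1CCCc3cccnc31)C2` differs from compound 3 at a single place: (oxetan-3-yl)amino in place of diethylamino on a saturated chain carbon, four bonds along the chain from an amine nitrogen. Among the measured compounds shown here, the one measured change at that same place, a number 58 percentage points lower from compound 1 to compound 3 (beyond the scatter), is large, and the step of a number 63 percentage points lower from compound 1 to compound 2 (beyond the scatter) is of similar size. The new group in compound 4 matches neither end group of compound 1 or compound 3, so only part of that size seems reasonable. In this assay the expected change is a rise, a number 24 percentage points higher from compound 3 to compound 4 (beyond the scatter). For compound 4 the estimated value is 30%, with an expected range from 8% to 62%.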

Compound 4, percent of the compound remaining: 27%
Estimate against measurement, compound 4: 3 percentage points above, and the stated range covers the measured number.
By their numbers in this assay, from the lowest: compounds 2 and 3 (each within the scatter of the next); then compound 4; then compound 1.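

In this assay, not every substituted end group on this chain falls as low as diethylamino: (oxetan-3-yl)amino in its place gives a number 21 percentage points higher from compound 3 to compound 4 (beyond the scatter) here, and the comparison with the other low compound gives a number 26 percentage points higher from compound 2 to compound 4 (beyond the scatter) as well. Even so, oxetan-3-yl on the end nitrogen of compound 1 still costs much, with a number 37 percentage points lower from compound 1 to compound 4 (beyond the scatter) on this read-out, so the plain amino end remains highest of the four. Nothing available explains these shifts. From the compounds shown here alone, whether methylamino or a morpholine ring at this place would stay closer to compound 1 remains open.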